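Chloro in place of nitro: compound 2 to compound 3

The source may report more compounds than this note shows. Statements on the series, on what has been measured and on what is new or still open speak of the compounds shown alone.

Measured in a functional assay on Jurkat cells (Homo sapiens) for antiproliferative activity, read by MTT assay, with a stated time of 72 h (on this read-out higher numbers stand for weaker inhibition and lower numbers for stronger inhibition), so far:
- compound 1 `COc1ccc(-c2ncnn2-c2cc(OC)c(OC)c(OC)c2)cc1` gives 50 nM here
- compound 2 `COc1cc(-n2ncnc2-c2cccc([N+](=O)[O-])c2)cc(OC)c1OC` gives > 10000 nM here, a limit

Compound 2 sits at the limit of > 10000 nM in this assay, at which 1 of the 2 values shown sits, and so has no number to start from. Compound 3 `COc1cc(-n2ncnc2-c2cccc(Cl)c2)cc(OC)c1OC` carries chloro in place of nitro on an aromatic carbon, meta to a large group (chloro in place of nitro on an aromatic carbon). Going by the values given here, no measured pair isolates this change, so the expectation rests on little. Compound 1 reaches strong inhibition (50 nM), which leaves room for some gain in this assay but does not point to a full recovery. The expected change is a moderate one toward stronger inhibition (an at least 3.3-fold lower number from compound 2 to compound 3 (0.52 log units; beyond the scatter)). Compound 3 is estimated at 3000 nM (range 300 nM to 10000 nM). A reading that gives only a limit again remains a real possibility.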

Compound 3, half-maximal inhibitory concentration: > 10000 nM
Compound 3: no number, only a limit; the forecaster's own chance of this, stated with the estimate: 40%; at least 3.3-fold (0.52 log units) between middle value and limit.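

In this assay compound 3 gives > 10000 nM, which is a limit and not a number. Taking 3-chlorophenyl in place of 4-methoxyphenyl gives an at least 200-fold higher number from compound 1 to compound 3 (2.30 log units; beyond the scatter) in this read-out, so a second group at this place, meta to a large group, now stands with nitro on the far side of a large loss. The step for chloro in place of nitro cannot be read, and neither group can be ranked over the other: the limit of > 10000 nM in this assay, at which 2 of the 3 values shown sit.

Open is whether the loss with 3-chlorophenyl belongs to chloro itself or to where it sits on the ring, as no compound shown changes one and keeps the other. Equally open, as far as these compounds go, is how an amine or a hydroxyl at this place would read in this assay and whether either would come back to a measurable value.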